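The source may hold more compounds than are shown below. What is called first, only, known or untested is meant among the compounds shown, and "the series" means these compounds.

Compound 1 `CC(C)C1CN(C(=O)Nc2ccc(Cl)cc2)CCN1/C(=N/C#N)Nc1cccc2ncccc12` gives 121 nM
Compound 2 `N#C/N=C(\Nc1cccnc1)N1CCN(C(=O)Nc2ccc(Cl)cc2)C(c2ccccc2)C1` gives "not determined" (no result reported)

Going by the values given here, in a functional assay on blood (Homo sapiens) for inhibition (on this read-out higher numbers stand for weaker inhibition and lower numbers for stronger inhibition), compound 1 gives 121 nM as the only number so far. With no result for compound 2, compound 1 cannot yet be ranked against anything.

Compound 3 `CC(C)C1CN(C(=O)Nc2ccc(Cl)cc2)CCN1/C(=N/C#N)Nc1cccc2nc(F)ccc12` differs from compound 1 in one place (fluoro in place of hydrogen on an aromatic carbon): fluoro in place of hydrogen on an aromatic carbon, next to the ring nitrogen, turning quinolin-5-yl into 2-fluoroquinolin-5-yl. Among the compounds with values here, no measured pair shows what this change does, so no step beyond the usual scatter is expected in either direction. The estimated step of a 1.2-fold lower number from compound 1 to compound 3 (0.08 log units; within the scatter) is correspondingly small. Compound 3 is expected at 100 nM (estimated range 35 nM to 300 nM).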

Compound 3, half-maximal inhibitory concentration: 2640 nM
Estimate against measurement, compound 3: 26-fold (1.42 log units) below; the whole stated range lies below it.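

In this assay, placing a single fluoro on the aromatic carbon next to the ring nitrogen, which turns quinolin-5-yl into 2-fluoroquinolin-5-yl, gives a 22-fold higher number from compound 1 to compound 3 (1.34 log units; beyond the scatter). Inhibition at this position is therefore sensitive: adding one heavy atom here is enough to weaken it well beyond the scatter. No information at hand explains this loss. On these data alone, whether a methyl, a chlorine or an amine on this same carbon would weaken inhibition as much remains open. So does the effect of fluoro on the other carbons of this ring.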